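Adding a Second Phenyl Where a Hydrogen Sat

The source may report more compounds than this note shows. Statements on the series, on what has been measured and on what is new or still open speak of the compounds shown alone.

Compound 3 `N#C/N=C(/NCCCCc1c[nH]cn1)NCCCc1ccccc1` was examined in an in vitro functional assay on Sf9 cells for antagonist activity at histamine H2 receptor (Homo sapiens) (on this read-out higher numbers stand for higher potency (the scale is a negative logarithm) and lower numbers for lower potency), where compound 3 gives 5.25. This places it level with compound 1 `N#C/N=C(\NCCCc1ccccc1)NCCCc1c[nH]cn1`, because in this assay compound 1 gives 5.25, and the step from the one to the other is no change at the digits printed from compound 1 to compound 3 (within the scatter). Compound 2 `N#C/N=C(/NCCCc1c[nH]cn1)NCCC(c1ccccc1)c1ccccc1` differs from compound 1 only by a phenyl in place of hydrogen on a saturated chain carbon bound to an aromatic carbon and a saturated chain carbon. In this assay compound 2 reaches only a limit of the assay, < 5. The step of a number at least 0.25 log units lower from compound 1 to compound 2 (that floor lies within the scatter) is therefore known only as a floor, and it rests on the limit described by the limit of < 5 in this assay, at which 1 of the 3 values shown sits.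

Compound 4 `N#C/N=C(/NCCCCc1c[nH]cn1)NCCC(c1ccccc1)c1ccccc1` applies the same change to compound 3: phenyl in place of hydrogen on a saturated chain carbon bound to an aromatic carbon and a saturated chain carbon. Within the data shown here, the single measured step that bears on it is the one from compound 1 to compound 2, a fall whose true size is hidden by the limit. Compound 4 is accordingly expected to lose potency, by an estimated a number 0.45 log units lower from compound 3 to compound 4 (beyond the scatter), and most probably to sit at the limit again. For compound 4 the estimate in this assay is 4.8, expected to lie between 4.3 and 5.3.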

Compound 4, negative logarithm of the antagonist equilibrium constant: 5
Compound 4: the middle estimate sits 0.20 log units below what was measured; low and high end bracket the measured number.
By their numbers in this assay, from the lowest: compounds 4, 1 and 3 (each within the scatter of the next).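

In this assay, the phenyl change now has a readable size, where earlier it was known only as a floor: it comes out as a number 0.25 log units lower from compound 3 to compound 4 (within the scatter). On the core of compound 3, then, a second phenyl in place of hydrogen at this saturated chain carbon shows no fall beyond the scatter. Whether the two cores respond to the change alike stays unsettled: the same change on two cores in this assay, a number at least 0.25 log units lower (that floor lies within the scatter) from compound 1 to compound 2 and a number 0.25 log units lower (within the scatter) from compound 3 to compound 4; the limit leaves it open whether they differ

The remaining new step is a number no lower from compound 2 to compound 4 (the limit leaves the size open), and its size cannot be read. On these data alone, compound 2 gives only a limit, so the effect of the longer imidazole-bearing chain on the diphenyl compounds stays open. Also open, as far as these compounds go, is how this carbon would tolerate a group other than phenyl, such as an amine or a carboxylic acid, in place of that hydrogen.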